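A few compounds are considered here, and "the series" means these few. Any claim that something is new, unique, unknown or untested is made for them only; others in the source may bear on it.

Measured in a physicochemical assay for solubility; a lower number here means a less soluble compound, a higher number a more soluble compound:
- compound 1 `CC(C)(C)OC(=O)N1CCC[C@H]1C(=O)N1CCC(NS(=O)(=O)c2cc(S(=O)(=O)c3ccccc3)ccc2C(F)(F)F)CC1`: 25000 nM
- compound 2 `CC(C)C(=O)N1CCC[C@H]1C(=O)N1CCC(NS(=O)(=O)c2cc(S(=O)(=O)c3ccccc3)ccc2C(F)(F)F)CC1`: 100000 nM
- compound 3 `O=C([C@@H]1CCCN1C(=O)c1ccncc1)N1CCC(NS(=O)(=O)c2cc(S(=O)(=O)c3ccccc3)ccc2C(F)(F)F)CC1`: 100000 nM

Compound 3 stands level with compound 2 at the top of these three numbers, and compound 1 is the lowest. Compound 4 `CC(C)(C)NC(=O)N1CCC[C@H]1C(=O)N1CCC(NS(=O)(=O)c2cc(S(=O)(=O)c3ccccc3)ccc2C(F)(F)F)CC1` follows from compound 3 by (tert-butyl)amino in place of pyridin-4-yl on a carbonyl carbon. All measured steps concern this carbonyl carbon. Replacing tert-butoxy gave a 4.0-fold higher number from compound 1 to compound 2 (0.60 log units; beyond the scatter) and a 4.0-fold higher number from compound 1 to compound 3 (0.60 log units; beyond the scatter), while isopropyl and pyridin-4-yl differ by no change at the digits printed from compound 2 to compound 3 (within the scatter). Among the compounds with values here, compound 1 is the closest precedent by group name, but no measured compound carries (tert-butyl)amino. In this assay a modest drop is therefore expected, estimated as a 2.2-fold lower number from compound 3 to compound 4 (0.35 log units; beyond the scatter). For compound 4 the estimated value is 45000 nM, with an expected range of 15000 nM to 100000 nM.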

Compound 4, solubility: 50000 nM
The estimate for compound 4 lay 1.1-fold (0.05 log units) below the measured number; the measured number falls inside the stated range.
By their numbers in this assay, from the lowest: compounds 1, 4, 2 and 3 (each within the scatter of the next, the first and the last beyond it).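

In this assay, (tert-butyl)amino on this carbonyl carbon stands within the scatter of all three earlier groups: pyridin-4-yl (a 2.0-fold lower number from compound 3 to compound 4 (0.30 log units; within the scatter)), isopropyl (a 2.0-fold lower number from compound 2 to compound 4 (0.30 log units; within the scatter)) and tert-butoxy (a 2.0-fold higher number from compound 1 to compound 4 (0.30 log units; within the scatter)). The earlier compounds shown here split this position into two levels, with tert-butoxy beyond the scatter of the other two groups, whereas compound 4 cannot be placed with either level. No supporting measurement bears on this result.

Still open, from the compounds shown here alone, is how a carboxylic acid or a primary amine on this carbonyl carbon would read out. Going by these compounds, a longer chain in place of tert-butyl on the amino nitrogen is equally open.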